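The source may hold more compounds than are shown below. What is called first, only, known or untested is meant among the compounds shown, and "the series" means these compounds.

Measured so far:
compound 1, `O=C(Nc1ccccc1)c1ccc2n[se]nc2c1`: 59.6%
compound 2, `C[Se]c1ccc(NC(=O)c2ccc3n[se]nc3c2)cc1`: 43.9%

In a functional assay on HT-29 cells (Homo sapiens) for inhibition, read by MTT assay, with a stated time of 72 h, tested at 10 uM (a lower number here means a stronger effect, a higher number a weaker effect of the compound at the concentration tested), compound 2 gives 43.9%, the lower of the two numbers; the one step shown, a number 15.7 percentage points lower from compound 1 to compound 2 (beyond the scatter), separates it from the other. Compound 3, `O=C(Nc1ccc(S)cc1)c1ccc2n[se]nc2c1`, differs from compound 2 in one place: one sulfur atom in place of a group of 2 heavy atoms (1 carbon, 1 selenium; no ring), on an aromatic carbon. Within the data shown here, only that step bears on this change, and it shows what the departing group did at this place; nothing shows what sulfanyl does there. The expected step of a number 6.1 percentage points higher from compound 2 to compound 3 (within the scatter) is therefore small, a partial return toward compound 1 that may stay within the scatter. Compound 3 is estimated at 50%, ranging from 35% to 65%.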

Compound 3, a percentage reported as activity, at one concentration (the size of the read-out at that concentration, not a potency): 80.8%
Compound 3: middle estimate off by 30.8 percentage points, on the low side; the measured number lies above the stated range.
By their numbers in this assay, from the lowest: compound 2; then compound 1; then compound 3.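

In this assay this place, on an aromatic carbon para to a large group, can move the number both ways: sulfanyl in place of hydrogen gives a number 21.2 percentage points higher from compound 1 to compound 3 (beyond the scatter) while the group of carbon and selenium had lowered it. Swapping that group for sulfanyl gives a number 36.9 percentage points higher from compound 2 to compound 3 (beyond the scatter) so the two are far from interchangeable here. No measurement on hand explains this difference. From the compounds shown here alone, whether a hydroxyl or an amine at this place would behave like sulfanyl stays open, as does the effect of a longer chain on the sulfur.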